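A few compounds are considered here, and "the series" means these few. Any claim that something is new, unique, unknown or untested is made for them only; others in the source may bear on it.

Measured in a functional assay on NCI-H460 cells (Homo sapiens) for inhibition, read by sulforhodamine B assay, with a stated time of 48 h; on this read-out higher numbers stand for weaker inhibition of growth and lower numbers for stronger inhibition of growth:
Compound 1 `CCOC(=O)c1nn(-c2ccccc2)c(-c2ccc(F)cc2)c1CNC(C)(C)C`: 365000 nM; 179000 nM (2 entries)
Compound 2 `CCOC(=O)c1nn(-c2ccc(Cl)cc2)c(-c2ccc(F)cc2)c1CNC(C)(C)C`: 344000 nM; > 537000 nM (2 entries)
Compound 3 `CC(C)(C)NCc1c(C(=O)O)nn(-c2ccccc2)c1-c1ccc(F)cc1`: > 680000 nM, a limit of the assay

Compound 3 has no single number in this assay. Its further entries give no single number either, and the value shown for it is a limit.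

Compound 4 `COc1ccc(-c2c(CNC(C)(C)C)c(C(=O)O)nn2-c2ccccc2)cc1` differs from compound 3 at one place, with methoxy in place of fluoro on an aromatic carbon, para to a large group: methoxy in place of fluoro on an aromatic carbon. The same difference can be read as 4-fluorophenyl to 4-methoxyphenyl.

Going by the values given here, no pair of measured compounds shows this change, or any other single change, so the data give no measured size for it. The expectation therefore starts from compound 3 and its limit of > 680000 nM. Compound 1 also sits high on this read-out, with entries of 365000 nM; 179000 nM (2 entries). No step beyond the usual scatter is expected, and no direction can be favoured: the expected move is an at least 1.2-fold lower number from compound 3 to compound 4 (0.09 log units; that floor lies within the scatter). A limit rather than a number is the likeliest report for compound 4. If a number is obtained, the estimate for compound 4 is 550000 nM, with an expected range of 250000 nM to 800000 nM.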

Compound 4, concentration for 50% growth inhibition: > 659000 nM
Compound 4 was reported as a limit; the forecaster's own chance of this, stated with the estimate: 70%; at least 1.1-fold (0.07 log units) between middle value and limit.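

Compound 3 is reported at > 680000 nM as a limit of the assay. Compound 4 is likewise reported at > 659000 nM as a limit of the assay. With only these two limits, no step can be read between compound 3 and compound 4. The compounds shown leave open whether methoxy in place of fluoro on an aromatic carbon changes growth inhibition at all, and in which direction.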